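Urea to amide on the shared core

A few compounds are considered here, and "the series" means these few. Any claim that something is new, unique, unknown or untested is made for them only; others in the source may bear on it.

Compound 2 `COc1cc(Cl)cc(-c2nn(-c3cccc(NC(=O)Nc4cccc(C(F)(F)F)c4)c3)cc2-c2ccncc2)c1`: 100%
Compound 1 `COc1cc(Cl)cc(-c2nn(-c3cccc(NC(=O)Nc4ccc(Cl)c(C(F)(F)F)c4)c3)cc2-c2ccncc2)c1`: 91%

In a functional assay on OVCAR-3 cells (Homo sapiens) for inhibition, read by sulforhodamine B assay, with a stated time of 48 h, tested at 0.01 uM (a lower number here means a stronger effect, a higher number a weaker effect of the compound at the concentration tested), compound 2 gives 100%, the highest of the two numbers, with compound 1 nearest; the step of a number 9 percentage points higher from compound 1 to compound 2 (within the scatter) lies within the scatter. Compound 3 `COc1cc(Cl)cc(-c2nn(-c3cccc(NC(=O)c4cccc(C(F)(F)F)c4)c3)cc2-c2ccncc2)c1` differs from compound 2 by 3-(trifluoromethyl)phenyl in place of (3-(trifluoromethyl)phenyl)amino on a carbonyl carbon. Among the measured compounds shown here, no measured step touches this carbonyl position, so nothing here points in either direction. For compound 3 the expected step is a number 5 percentage points lower from compound 2 to compound 3 (within the scatter). Compound 3 is therefore estimated at 95%, with a range of 75% to 110%.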

Compound 3, a percentage reported as activity, at one concentration (the size of the read-out at that concentration, not a potency): 105%
Beside the measured number, compound 3's estimate is 10 percentage points below it; the measured number falls inside the stated range.
By their numbers in this assay, from the lowest: compounds 1, 2 and 3 (each within the scatter of the next, the first and the last beyond it).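

Taking out the amino nitrogen on the carbonyl carbon, and with it a hydrogen-bond donor, gives in this assay a step of a number 5 percentage points higher from compound 2 to compound 3 (within the scatter), so urea and amide are not separated at this position. The larger step of a number 14 percentage points higher from compound 1 to compound 3 (beyond the scatter) also removes the 4-chloro group, so it cannot be assigned to either change alone. Nothing available accounts for these values.

Still open, as far as these compounds go, is how the amide with the 4-chloro-3-(trifluoromethyl)phenyl group compares with compound 1. Also open, from the compounds shown here alone, is what a carbonyl substituent such as a piperazine amine or a carboxylic acid would give.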